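Ester to Amide at the End of the Acyl Chain

The compounds below may be only part of what the source reports. "The series", "measured", "known", "first", "only" and "open" are said of these compounds alone.

Compound 1 `Cc1cn([C@@H]2O[C@H](CO[Si](C)(C)C(C)(C)C)[C@@]3(OS(=O)(=O)C=C3N)[C@H]2O[Si](C)(C)C(C)(C)C)c(=O)n(C(=O)OC(C)(C)C)c1=O`: 26000 nM
Compound 2 `COC(=O)CCCC(=O)n1c(=O)c(C)cn([C@@H]2O[C@H](CO[Si](C)(C)C(C)(C)C)[C@@]3(OS(=O)(=O)C=C3N)[C@H]2O[Si](C)(C)C(C)(C)C)c1=O`: 9900 nM

In an ADME assay on CCRF-CEM cells (Homo sapiens) for cytotoxicity, with a stated time of 4 days (a lower number here means that less compound is tolerated, a higher number that more compound is tolerated), compound 2 holds the lower of the two numbers; the step of a 2.6-fold lower number from compound 1 to compound 2 (0.42 log units; beyond the scatter) separates it from compound 1, which exchanged tert-butoxy for 3-(methoxycarbonyl)propyl on a carbonyl carbon. Compound 3 `Cc1cn([C@@H]2O[C@H](CO[Si](C)(C)C(C)(C)C)[C@@]3(OS(=O)(=O)C=C3N)[C@H]2O[Si](C)(C)C(C)(C)C)c(=O)n(C(=O)CCCC(=O)N(C)C)c1=O` differs from compound 2 by dimethylamino in place of methoxy on a carbonyl carbon. Going by the values given here, no measured step concerns such an exchange, so the single step seen gives no guidance, and the account expects no change beyond the scatter, that is no change at the digits printed from compound 2 to compound 3 (within the scatter). Compound 3 is therefore estimated at 9900 nM, within 4000 nM to 25000 nM.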

Compound 3, half-maximal cytotoxic concentration: 9500 nM
For compound 3 the middle estimate is 1.0-fold (0.02 log units) above the measured one; the measured number falls inside the stated range.
By their numbers in this assay, from the lowest: compounds 3 and 2 (each within the scatter of the next); then compound 1.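

In this assay the exchange of methoxy for dimethylamino on a carbonyl carbon makes no difference that can be read (a 1.0-fold lower number from compound 2 to compound 3 (0.02 log units; within the scatter)), so the ester and the amide at the end of the acyl chain cannot be told apart here. The amide also keeps the separation from the tert-butoxy carbonyl compound (a 2.7-fold lower number from compound 1 to compound 3 (0.44 log units; beyond the scatter)), as the ester did. No evidence at hand gives a reason for either result. The compounds shown leave open whether a carboxylic acid or a primary amine at the chain end, or a longer chain, would shift the number.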